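A few compounds are considered here, and "the series" means these few. Any claim that something is new, unique, unknown or untested is made for them only; others in the source may bear on it.

Of the compounds shown here, three sharing one core have been measured in an assay on mitochondria from L6 cells (Rattus norvegicus) for activation, with a stated time of 90 min; a higher number here means that more compound is needed for the effect, a lower number that less compound is needed. Compound 1 `CCc1ccc(Nc2nc3nonc3nc2O)c(F)c1` gives 6700 nM, compound 2 `CCCCCc1ccc(Nc2nc3nonc3nc2O)c(F)c1` gives 1500 nM, and compound 3 `Cc1cc(OC(F)(F)F)ccc1Nc1nc2nonc2nc1O` gives 4600 nM. Compound 3 thus stands second highest of the three numbers: its nearest neighbour is compound 1, a gap within the scatter, and its furthest is compound 2, a gap beyond it. Among the compounds with values here, the only step recorded between two compounds differing in one place is a 4.5-fold lower number from compound 1 to compound 2 (0.65 log units; beyond the scatter). Compound 4 `Oc1nc2nonc2nc1Nc1ccc(OC(F)(F)F)cc1F` has not yet been measured in this assay. It differs from compound 3 by fluoro in place of methyl on an aromatic carbon. Within the data shown here, no measured step bears on this change; the step from compound 1 to compound 2 concerns a saturated chain, not an aromatic carbon, so it offers no guide to size or direction here. On this basis compound 4 is expected to show a step of no change at the digits printed from compound 3 to compound 4 (within the scatter) in this assay, meaning none beyond the scatter. Compound 4 is therefore estimated at 4600 nM, with a range from 1800 nM to 12000 nM.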

Compound 4, half-maximal effective concentration: 2300 nM
Compound 4: the middle estimate sits 2.0-fold (0.30 log units) above what was measured; low and high end bracket the measured number.
By their numbers in this assay, from the lowest: compounds 2, 4, 3 and 1 (each within the scatter of the next, the first and the last beyond it).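

In this assay, fluoro in place of methyl on this aromatic carbon, ortho to a large group, gives a 2.0-fold lower number from compound 3 to compound 4 (0.30 log units; within the scatter), so this first reading of the change shows no shift that can be told from the scatter. With fluoro held at that carbon, trifluoromethoxy in place of the chain can now be read as well: replacing pentyl gives a 1.5-fold higher number from compound 2 to compound 4 (0.19 log units; within the scatter), within the scatter, whereas replacing ethyl gives a 2.9-fold lower number from compound 1 to compound 4 (0.46 log units; beyond the scatter), beyond it. Nothing available explains these steps.

As far as these compounds go, the fluoro for methyl change rests on a single pair, so it remains open whether it would read the same with ethyl or pentyl in place of trifluoromethoxy. From the compounds shown here alone, how chloro, methoxy or an amine would fare on this aromatic carbon also remains open.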